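Tert-Butyl Analogue in a Cytotoxicity Screen

This account rests on a few compounds, and the source may have more. Where it says the series, first, only, none or still open, it means among the compounds named here.

Measured compounds:
- Compound 1, `CCCCCCCCOc1ccc(C(=O)N/N=C/c2ccc([N+](=O)[O-])o2)cc1`: in an ADME assay on U2OS cells (Homo sapiens) for cytotoxicity (on this read-out higher numbers stand for lower toxicity in this test and lower numbers for higher toxicity in this test), compound 1 gives > 200000 nM; this is a limit of the assay, not a number.
- Compound 2, `CCCCCCc1ccc(C(=O)N/N=C/c2ccc([N+](=O)[O-])o2)cc1`: in this assay compound 2 gives > 200000 nM; this too is a limit of the assay.
- Compound 3, `CCCCCCC1CCC(C(=O)N/N=C/c2ccc([N+](=O)[O-])o2)CC1`: in this assay compound 3 gives > 200000 nM; again a limit of the assay.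

Within the data shown here, compound 2 therefore stands at the limit of this assay, where every value so far sits (the limit of > 200000 nM in this assay, at which 3 of the 3 values shown sit). Among the measured compounds shown here, the one step that connects measured compounds, a step that the two limits leave unreadable from compound 1 to compound 2, cannot be read in size because both ends are limits. Compounds 1 and 3 likewise show only the same limit.

The next compound, compound 4, `CC(C)(C)c1ccc(C(=O)N/N=C/c2ccc([N+](=O)[O-])o2)cc1`, differs from compound 2 by one change: tert-butyl in place of hexyl on an aromatic carbon. For the measured compounds named here, no measured step gives a readable size to carry over, and every compound with this core has stayed at the limit. Compound 4 is therefore expected to give 250000 nM, within 150000 nM to 500000 nM, most likely again reported only as a limit. The expected step that the limit leaves unreadable from compound 2 to compound 4 is thus estimated to be none beyond the scatter.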

Compound 4, half-maximal cytotoxic concentration: > 200000 nM
Compound 4: only a limit was reported; the forecaster's own chance of this, stated with the estimate: 85%; the middle value is on the limit's open side.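

In this assay compound 4 gives > 200000 nM, a limit of the assay and not a number. Among these compounds, no step from compound 1 or compound 2 to compound 4 can be read in size. The compounds shown leave open whether octyloxy, hexyl and tert-butyl differ at all on this read-out.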